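The source may hold more compounds than are shown below. What is called first, only, known or untested is meant among the compounds shown, and "the series" means these compounds.

Compound 1 `COc1ccc(OC)c(S(=O)(=O)NC(=O)c2ccc(Cn3ccc4ccc(NC(=O)CC5CCCC5)cc43)c(OC)c2)c1` sits at the top of the two values available in this series. In a functional assay (trachea) for antagonist activity, with Cavia porcellus as the target (a lower number here means a less potent compound, a higher number a more potent compound, by a factor of ten per unit of this negative logarithm), compound 1 gives 9.1, while compound 2 `CCCCOC(=O)Nc1ccc2cnn(Cc3ccc(-c4nn[nH]n4)cc3OC)c2c1`, built on a different core, gives 7.1 in this assay; the gap between the two readings is well beyond the usual scatter, so compound 1 is the more potent of the pair on present numbers. Among the measured compounds shown here, no two measured compounds differ in a single place, so nothing is yet known about how any single change moves this assay.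

For the measured compounds named here, compound 3 `COc1cc(C(=O)NS(=O)(=O)c2ccccc2C)ccc1Cn1ccc2ccc(NC(=O)CC3CCCC3)cc21` is the first such single-point variation from compound 1. The change is 2-methylphenyl in place of 2,5-dimethoxyphenyl on a sulfonyl sulfur. Both rings keep one six-membered aromatic carbon ring, and the net charge is unchanged; what goes away are the two hydrogen-bond acceptors counted for the leaving group. Going by the values given here, with no comparable step on record, the direction must rest on the structural change alone: a modest loss of potency is expected, with a number 0.40 log units lower from compound 1 to compound 3 (beyond the scatter) as the estimated step from compound 1 to compound 3. For compound 3 the expected value in this assay is 8.7, with a plausible range from 8 to 9.3.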

Compound 3, negative logarithm of the antagonist equilibrium constant: 9.9
Compound 3: middle estimate off by 1.20 log units, on the low side, and the stated range ends below it.
By their numbers in this assay, from the lowest: compound 2; then compound 1; then compound 3.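

The sulfonyl sulfur now has its first single-point reading: in this assay, 2-methylphenyl in place of 2,5-dimethoxyphenyl gives a number 0.80 log units higher from compound 1 to compound 3 (beyond the scatter), so the group on this sulfur clearly affects potency in this series. The entering group has fewer heavy atoms and lacks the two hydrogen-bond acceptors counted for the leaving group, yet potency does not fall, so those acceptors are not required for a high reading in compound 3. No measurement on hand accounts for the gain, and this single step cannot separate the loss of the two methoxy groups from the gain of the methyl group.

Still open, going by these compounds, is whether a plain phenyl ring on the sulfonyl sulfur keeps the reading of compound 3, which would show whether the methyl group matters or only the absence of the two methoxy groups. Also open, on these data alone, is whether this position needs an aromatic ring at all, a question that a butyl chain on the same sulfur would test directly.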